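The source may report more compounds than this note shows. Statements on the series, on what has been measured and on what is new or still open speak of the compounds shown alone.

Measured compounds: compound 1 `CCC1=C(O)c2c(oc(-c3ccc(C(C)C)cc3)cc2=O)C(CC)(CC)C1=O` gives 8.13 uM in a functional assay on KB cells (Homo sapiens) for antiproliferative activity, read by sulforhodamine B assay, with a stated time of 3 days; on this read-out lower numbers stand for an effect already at smaller amounts and higher numbers for an effect only at larger amounts of compound; compound 2 `CCC1=C(O)c2c(oc(-c3ccc(O)cc3)cc2=O)C(CC)(CC)C1=O` gives 20.6 uM. Compound 3 `CCC1=C(O)c2c(oc(-c3cccc(OC(F)(F)F)c3)cc2=O)C(CC)(CC)C1=O` reaches only a limit, > 47.4 uM.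

Compound 1 has the lowest of the two numbers shown; its nearest neighbour is compound 2, with a 2.5-fold higher number from compound 1 to compound 2 (0.40 log units; beyond the scatter). Compound 4 `CCC1=C(O)c2c(oc(-c3ccccc3C)cc2=O)C(CC)(CC)C1=O` differs from compound 1 in one place: 2-methylphenyl in place of 4-isopropylphenyl on an aromatic carbon. No measured step exchanges the 4-isopropylphenyl for the 2-methylphenyl; the only step shown, from compound 1 to compound 2, concerns a different change and was modest. For compound 4 a step of similar size, toward a higher number, is therefore expected, a 1.7-fold higher number from compound 1 to compound 4 (0.24 log units; within the scatter). Compound 4 is estimated at 14 uM, within 6 uM to 35 uM.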

Compound 4, concentration for half-maximal effect: 40.9 uM
Compound 4: the middle estimate sits 2.9-fold (0.47 log units) below what was measured; measured number above the stated range.
By their numbers in this assay, from the lowest: compound 1; then compounds 2 and 4 (each within the scatter of the next). At a limit, above all of these: compound 3.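

In this assay, a carbon-only group at this position does not preserve the number of compound 1: putting 2-methylphenyl in place of 4-isopropylphenyl gives a 5.0-fold higher number from compound 1 to compound 4 (0.70 log units; beyond the scatter). A hydroxy group is therefore not needed for such a rise, and compound 2 and compound 4 cannot be separated, with a 2.0-fold higher number from compound 2 to compound 4 (0.30 log units; within the scatter). Compound 3 remains only a limit: the limit of > 47.4 uM in this assay, at which 1 of the 4 values shown sits.

The 2-methylphenyl changes both the size of the group and where it sits, so these two effects remain unseparated. Plain phenyl, 4-methylphenyl or 4-aminophenyl at this position remains open.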